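Removing the oxan-2-yl group from compound 2

The source may report more compounds than this note shows. Statements on the series, on what has been measured and on what is new or still open speak of the compounds shown alone.

Of the compounds shown here, two sharing one core have been measured so far, compound 1 (`COc1cc([C@@H]2Oc3c(OC)cc(C(C)=O)cc3[C@H]2CO[C@@H]2O[C@H](CO)[C@@H](O)[C@H](O)[C@H]2O)cc(OC)c1O`) and compound 2 (`COc1cc([C@@H]2Oc3c(OC)cc(C(C)=O)cc3[C@H]2CO)cc(OC)c1O[C@@H]1O[C@H](CO)[C@@H](O)[C@H](O)[C@H]1O`). In a functional assay on RAW264.7 cells (Mus musculus) for inhibition, read by Griess assay, with stated times of 1 h and 24 h (a higher number here means a weaker inhibitor, a lower number a stronger inhibitor), compound 1 gives 55800 nM and compound 2 gives 32400 nM. For the measured compounds named here, these two values lie within the scatter of each other, so compound 2 stands level with the only other measured member of the series.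

The next compound is compound 3 (`COc1cc([C@@H]2Oc3c(OC)cc(C(C)=O)cc3[C@H]2CO)cc(OC)c1O`). The change is hydrogen in place of 3,4,5-trihydroxy-6-(hydroxymethyl)oxan-2-yl on an oxygen on an aromatic ring, which places hydrogen in place of 3,4,5-trihydroxy-6-(hydroxymethyl)oxan-2-yl on an oxygen on an aromatic ring.

Compound 1 and compound 2 both carry this group, so the data hold no direct measure of its removal. Any expectation for this assay is therefore tentative. A modest shift toward a lower number is expected, and the estimated step of a 1.8-fold lower number from compound 2 to compound 3 (0.26 log units; within the scatter) may not clear the scatter. The uncertainty on this step is wide in both directions. For compound 3 the expected value is 18000 nM, with an estimated range of 6000 nM to 50000 nM.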

Compound 3, half-maximal inhibitory concentration: 32300 nM
The estimate for compound 3 lay 1.8-fold (0.25 log units) below the measured number; measured number inside the range.
By their numbers in this assay, from the lowest: compounds 3, 2 and 1 (each within the scatter of the next).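

In this assay, removal of 3,4,5-trihydroxy-6-(hydroxymethyl)oxan-2-yl from the oxygen on an aromatic ring can now be read directly (  a 1.0-fold lower number from compound 2 to compound 3 (0.00 log units; within the scatter)), so at this position the hydroxy form and the form carrying the group stand level. The same group on an oxygen on a saturated carbon can also be read against hydrogen (a 1.7-fold lower number from compound 1 to compound 3 (0.24 log units; within the scatter)), so in neither place does this group, with its 11 heavy atoms and one six-membered non-aromatic ring, separate from hydrogen beyond the scatter. No independent measurement is available to explain why these three compounds stand level in this assay.

Still open is whether any group on the oxygen on an aromatic ring can move the number beyond the scatter, since the compounds shown cover only hydrogen and this one large group; a small methyl ether, an acetyl ester or a short chain ending in an amine or a carboxylic acid would test this. The same question stands for the oxygen on a saturated carbon, where a methyl ether or a longer alkyl chain would show whether that hydroxy can be replaced with any gain in this assay.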